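The source may hold more compounds than are shown below. What is called first, only, known or untested is meant among the compounds shown, and "the series" means these compounds.

Compound 3, whose structure is `COc1cc(NC(C)CCCNC(=O)NCc2ccccc2)c2ncccc2c1`, was tested in an ADME assay on HEL cells (Homo sapiens) for cytotoxicity (on this read-out higher numbers stand for lower toxicity in this test and lower numbers for higher toxicity in this test), and gave 100000 nM. Two companions share its core. Compound 2, `COc1cc(NC(C)CCCNC(=O)NCc2ccncc2)c2ncccc2c1`, gives 100000 nM in this assay, and the step of no change at the digits printed from compound 2 to compound 3 (within the scatter) is thus flat. Compound 1, `COc1cc(NC(C)CCCNC(=O)NC(c2ccccc2)c2ccccc2)c2ncccc2c1`, sits at > 100000 nM in this assay, which is a limit of the assay rather than a number. The step of a number no higher from compound 1 to compound 3 (the limit leaves the size open) therefore cannot be sized, a point made plain by the limit of > 100000 nM in this assay, at which 1 of the 3 values shown sits. Compound 3 thus stands level with compound 2 and at the ceiling the measured values reach.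

Compound 4, `COc1cc(NC(C)CCCNC(=O)NC2CCCCC2)c2ncccc2c1`, differs from compound 3 by cyclohexyl in place of benzyl on an amide-type nitrogen. Among the measured compounds shown here, the one readable step, that from compound 2 to compound 3, changed nothing on the ring attached to the amide-type nitrogen, and no measured step touches the replacement of an aromatic ring by a non-aromatic one. An account of compound 4 in this assay would therefore expect no step beyond the scatter, that is no change at the digits printed from compound 3 to compound 4 (within the scatter). Compound 4 is estimated at 100000 nM, with a range from 50000 nM to 200000 nM.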

Compound 4, minimum cytotoxic concentration: 100000 nM
Estimate against measurement, compound 4: no gap at the digits printed; measured number inside the range.
By their numbers in this assay, from the lowest: compounds 2, 3 and 4 (each within the scatter of the next).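

In this assay, the replacement of an aromatic ring by a non-aromatic one on an amide-type nitrogen gives no change at the digits printed from compound 3 to compound 4 (within the scatter), so cyclohexyl reads the same here as benzyl. The comparison with the nitrogen-containing ring of the (pyridin-4-yl)methyl group gives no change at the digits printed from compound 2 to compound 4 (within the scatter), which extends the flat reading at this position to a saturated carbon ring. Compound 1 carries a limit rather than a number, so steps to it cannot be read: the limit of > 100000 nM in this assay, at which 1 of the 4 values shown sits.

The compounds shown leave open whether any group on this amide-type nitrogen can bring the reading down, since none of them separates from the others beyond the scatter. Going by these compounds, a cyclohexyl ring bearing an amine or a carboxylic acid, or a longer chain between the ring and the nitrogen, remains untested by these values.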